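The source may hold more compounds than are shown below. What is called first, only, known or untested is meant among the compounds shown, and "the series" means these compounds.

Measured compounds:
- compound 1 `O=c1cc(-c2ccccc2)oc2cc(OCCCCNc3nc4ccccc4s3)cc(O)c12`: 4.75 ug/mL
- compound 2 `O=c1cc(-c2ccccc2)oc2cc(OCCCCNc3nc4ccc([N+](=O)[O-])cc4s3)cc(O)c12`: 6.44 ug/mL

Compound 1 stands as the lower of the two numbers in a functional assay on HeLa cells (Homo sapiens) for cytotoxicity, read by sulforhodamine B assay, with a stated time of 48 h (a higher number here means a weaker inhibitor, a lower number a stronger inhibitor), with compound 2 nearest; the two values lie within the scatter of each other, so no order between them can be claimed. Among the measured compounds shown here, the one measured step, a 1.4-fold higher number from compound 1 to compound 2 (0.13 log units; within the scatter), is the only guide on what a substituent at this position of the shared core does, and it did not move the number beyond the scatter.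

Compound 3 `O=C(O)c1ccc2nc(NCCCCOc3cc(O)c4c(=O)cc(-c5ccccc5)oc4c3)sc2c1` differs from compound 1 by carboxy in place of hydrogen on an aromatic carbon. For the measured compounds named here, no measured pair shows a carboxy group entering at any position, so the step from compound 1 to compound 2 is the only bearing, and it is a small one. The working expectation is therefore a step of about the same size, a modestly higher number, and compound 3 is estimated to give 6.5 ug/mL in this assay, with a range of 3.5 ug/mL to 14 ug/mL, which corresponds to an expected step of a 1.4-fold higher number from compound 1 to compound 3 (0.14 log units; within the scatter).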

Compound 3, half-maximal inhibitory concentration in the HeLa assay: 8.43 ug/mL
For compound 3 the middle estimate is 1.3-fold (0.11 log units) below the measured one; the measured number falls inside the stated range.
By their numbers in the HeLa assay, from the lowest: compounds 1, 2 and 3 (each within the scatter of the next).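

Among the compounds shown here, in the HeLa assay compound 3 gives 8.43 ug/mL; carboxy in place of hydrogen on an aromatic carbon gives a 1.8-fold higher number from compound 1 to compound 3 (0.25 log units; within the scatter) and, with carboxy in place of nitro, a 1.3-fold higher number from compound 2 to compound 3 (0.12 log units; within the scatter) so this aromatic carbon has now carried hydrogen, nitro and carboxy with no order among neighbouring compounds that can be claimed. The earlier pair showed this for nitro alone; the new compound adds a second, different group at the same place, and one that brings a hydrogen-bond donor, still without a step beyond the scatter. In a physicochemical assay, read by spectrophotometry, with a stated time of 25 min (on this read-out higher numbers stand for weaker inhibition and lower numbers for stronger inhibition), compound 1 gives 26.5 ug/mL and compound 3 gives 21.7 ug/mL; the same exchange gives a 1.2-fold lower number from compound 1 to compound 3 (0.09 log units; within the scatter) and so a second read-out also fails to separate carboxy from hydrogen, while nothing at hand offers a reason for either result.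

From the compounds shown here alone, whether an amine, a methoxy group or a chlorine on this aromatic carbon would also stay within the scatter remains open. Equally open, going by these compounds, is whether the same indifference to the substituent would hold with a longer chain joining the two halves of the molecule.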